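A few compounds are considered here, and "the series" means these few. Any claim that something is new, unique, unknown or untested is made for them only; others in the source may bear on it.

Measured so far in an ADME assay on microsomes from liver (Mus musculus) for metabolic stability, read by LC-MS, tested at 1 uM; on this read-out lower numbers stand for slow clearance and higher numbers for fast clearance:
- compound 1 `CCOC(=O)C1=C(C)N/C(=C/c2cc(C)n(-c3ccc(OC)cc3)c2C)C1=O`: 54 mL.min-1.g-1
- compound 2 `CCOC(=O)C1=C(C)N/C(=C/c2cc(C)n(-c3cccnc3)c2C)C1=O`: 82 mL.min-1.g-1

Within the data shown here, compound 1 gives the lower of the two numbers in this assay, and the only measured step, a 1.5-fold higher number from compound 1 to compound 2 (0.18 log units; within the scatter), stays within the scatter. Compound 3 `CCOC(=O)C1=C(C)N/C(=C/c2cc(C)n(-c3ccc(CN4CCCCC4)cc3)c2C)C1=O` differs from compound 1 by (piperidin-1-yl)methyl in place of methoxy on an aromatic carbon. Among the measured compounds shown here, no measured step covers this change, so nothing here tells how the number will move. The expected step is a 1.3-fold higher number from compound 1 to compound 3 (0.11 log units; within the scatter), with a wide range. Compound 3 is therefore estimated at 70 mL.min-1.g-1, between 30 mL.min-1.g-1 and 160 mL.min-1.g-1.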

Compound 3, intrinsic clearance in microsomes: 60 mL.min-1.g-1
The estimate for compound 3 lay 1.2-fold (0.07 log units) above the measured number; low and high end bracket the measured number.
By their numbers in this assay, from the lowest: compounds 1, 3 and 2 (each within the scatter of the next).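

On the aromatic carbon para to a large group, (piperidin-1-yl)methyl in place of methoxy gives a 1.1-fold higher number from compound 1 to compound 3 (0.05 log units; within the scatter) in this assay. So at this position, a much larger group carrying a six-membered non-aromatic ring still leaves the clearance number within the scatter of the methoxy compound. Nothing available explains this result.

On these data alone, it remains open whether an open-chain amine such as dimethylaminomethyl, or a carboxylic acid, on this same carbon would also stay within the scatter. A piperidine ring attached directly, without the connecting carbon, is also untested here.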